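Replacing the fluorobenzyl arm: a step without precedent

The source may report more compounds than this note shows. Statements on the series, on what has been measured and on what is new or still open speak of the compounds shown alone.

Compound 1, `Cc1cccc(N2CCN(c3nc(N)nc4sc(-c5ccc(F)cc5)nc34)CC2)c1`, is reported in a functional assay on cells (Lymphocyte, Homo sapiens) (a lower number here means a stronger inhibitor, a higher number a weaker inhibitor), only as a limit of the assay, > 10000 nM.
Compound 2, `Nc1nc(N2CCN(C(=O)COc3ccc(Cl)cc3)CC2)c2nc(Cc3ccc(F)cc3)sc2n1`, gives in this assay 700 nM.
Compound 3, `Nc1nc(N2CCN(C(=O)COc3ccc(Br)cc3)CC2)c2nc(-c3ccc(F)cc3)sc2n1`, gives in this assay 380 nM.

Among the two numbers, compound 2 holds the higher one, but its gap to compound 3 lies within the scatter, so the two are read as equivalent. Among the compounds with values here, the only measured step is an at least 26-fold lower number from compound 1 to compound 3 (1.42 log units; beyond the scatter), and it concerns the amine nitrogen in the ring; compound 1 contributes to it only (the limit of > 10000 nM in this assay, at which 1 of the 3 values shown sits).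

Compound 4, `CCCCCc1nc2c(N3CCN(C(=O)COc4ccc(Cl)cc4)CC3)nc(N)nc2s1`, has not been measured. Against compound 2 the change is butyl in place of 4-fluorophenyl on a saturated chain carbon bound to an aromatic carbon. Within the data shown here, no measured step touches this position. Compounds 2 and 3 do differ there, together with a second difference in the halogen, and their two values sit within the scatter of each other; that offers no direction. The exchange of a six-membered aromatic ring for a chain is a larger alteration than anything the pair shows, so a moderate loss is expected, with wide uncertainty. The expected step is a 2.1-fold higher number from compound 2 to compound 4 (0.33 log units; beyond the scatter). Compound 4 is therefore estimated at 1500 nM, between 400 nM and 6000 nM.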

Compound 4, half-maximal inhibitory concentration: 690 nM
Compound 4: the middle estimate sits 2.2-fold (0.34 log units) above what was measured, and the stated range covers the measured number.
By their numbers in this assay, from the lowest: compounds 3, 4 and 2 (each within the scatter of the next). At a limit, above all of these: compound 1.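

In this assay, within the data shown here, this position now has its first step that changes only one place: butyl in place of 4-fluorophenyl on a saturated chain carbon bound to an aromatic carbon gives a 1.0-fold lower number from compound 2 to compound 4 (0.01 log units; within the scatter), which is a result the earlier compounds could not give. Read one bond further out, 4-fluorobenzyl gives way to pentyl, so the six-membered aromatic ring and the fluorine both leave and a chain with no ring enters, yet in this pair the number stays within the scatter. So, for these two compounds with the 4-chlorophenoxy arm, an aromatic ring at this place is not needed to keep the value, although nothing shown here explains this tolerance.

From the compounds shown here alone, it remains open whether a longer chain, a single methyl group, or a pentyl chain ending in an amine or a carboxylic acid would hold the number in the same way. Going by these compounds, it is also open whether the exchange would behave alike with bromine in place of the chlorine of compound 2, as one pair sets no trend.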